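Swapping the aryl group on a hydrazone in a cytotoxicity screen

The source may hold more compounds than are shown below. What is called first, only, known or untested is meant among the compounds shown, and "the series" means these compounds.

Compound 1 `O=C(CSc1nnc(-c2ccncc2)o1)N/N=C/c1ccc(F)cc1` gives 170000 nM in an ADME assay on NIH3T3 cells (Mus musculus) for cytotoxicity, read by MTT assay, with a stated time of 24 h; on this read-out lower numbers stand for stronger inhibition and higher numbers for weaker inhibition.
Compound 2 `O=C(CSc1nnc(-c2ccncc2)o1)N/N=C/c1ccc(Cl)cc1` gives 181000 nM in this assay.
Compound 3 `COc1cccc(/C=N/NC(=O)CSc2nnc(-c3ccncc3)o2)c1` gives 179000 nM in this assay.

Compound 1 has the smallest of the three numbers, but the gaps to its neighbours are slight: a 1.1-fold higher number from compound 1 to compound 2 (0.03 log units; within the scatter) and a 1.1-fold higher number from compound 1 to compound 3 (0.02 log units; within the scatter), both within the scatter, as is a 1.0-fold lower number from compound 2 to compound 3 (0.00 log units; within the scatter). The three measured compounds are therefore not separated from one another.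

Compound 4 `O=C(CSc1nnc(-c2ccncc2)o1)N/N=C/c1cc(Cl)ccc1O` differs from compound 1 at the aryl group on the hydrazone carbon: 5-chloro-2-hydroxyphenyl in place of 4-fluorophenyl on a carbon with a double bond to nitrogen. For the measured compounds named here, two measured steps bear on this change. The step of a 1.1-fold higher number from compound 1 to compound 2 (0.03 log units; within the scatter) exchanges fluoro for chloro on that ring and moves nothing; the step of a 1.1-fold higher number from compound 1 to compound 3 (0.02 log units; within the scatter) exchanges the whole aryl group and moves nothing either. Nothing in these three compounds points to a change in this assay beyond the scatter. Compound 4 is therefore expected to give 175000 nM, within 100000 nM to 300000 nM, a step of a 1.0-fold higher number from compound 1 to compound 4 (0.01 log units; within the scatter) expected to stay within the scatter.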

Compound 4, half-maximal inhibitory concentration: 166000 nM
Estimate against measurement, compound 4: 1.1-fold (0.02 log units) above; the measured number falls inside the stated range.
By their numbers in this assay, from the lowest: compounds 4, 1, 3 and 2 (each within the scatter of the next).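

At the carbon with a double bond to nitrogen, 5-chloro-2-hydroxyphenyl carries a hydrogen-bond donor and a hydrogen-bond acceptor that 4-fluorophenyl lacks, yet this assay still does not separate the two compounds (a 1.0-fold lower number from compound 1 to compound 4 (0.01 log units; within the scatter)). The same holds against the other two aryl groups (a 1.1-fold lower number from compound 3 to compound 4 (0.03 log units; within the scatter); a 1.1-fold lower number from compound 2 to compound 4 (0.04 log units; within the scatter)), so four different aryl groups at this position, including one with two substituents, have produced no step beyond the scatter. No supporting measurement is available to explain this flat result.

On these data alone, all four compounds keep a six-membered aromatic ring at this position, so the effect of an amine, a carboxylic acid or a longer carbon chain there remains open. As far as these compounds go, whether a change to the shared core would move the number in this assay is also open.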